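The source may report more compounds than this note shows. Statements on the series, on what has been measured and on what is new or still open speak of the compounds shown alone.

Working notes on the series. In a functional assay on HEK293 cells for agonist activity at G-protein coupled receptor 39 (Homo sapiens), read by scintillation proximity assay and inositol phosphate accumulation, with a stated time of 75 min, in the presence of a further agent that is not named here (a lower number here means that less compound is needed, a higher number that more compound is needed for the effect), compound 1 `Cc1nn(-c2ncnc3nc[nH]c23)c2c1C(OCc1cc(F)cc3c1OCOC3)CC(=O)N2` gives 1.5 nM, the lowest number of the two measured; the nearest, compound 2 `CC(C)(C)c1cc(C(=O)N/N=C/c2ccc(O)cc2O)[nH]n1`, gives 240 nM, a gap beyond the usual scatter and one that links two unrelated structures, so it carries no single-change information. Compound 3 `COc1ccc(CCOC2CC(=O)Nc3c2c(C)nn3-c2ncnc3nc[nH]c23)cc1` keeps the core of compound 1 and differs by a group of 9 heavy atoms (8 carbon, 1 oxygen; one six-membered aromatic ring of carbon only) in place of a group of 11 heavy atoms (8 carbon, 2 oxygen, 1 fluorine; one six-membered non-aromatic ring with 2 hetero atoms, one six-membered aromatic ring of carbon only), on a saturated chain carbon bound to an oxygen on a saturated carbon. Within the data shown here, with no measured step of this kind to lean on, a moderate loss is expected rather than a gain, the step from compound 1 to compound 3 in this assay being estimated at a 10-fold higher number from compound 1 to compound 3 (1.00 log units; beyond the scatter). Compound 3 is therefore expected to give about 15 nM, within 4 nM to 60 nM.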

Compound 3, half-maximal effective concentration: 2 nM
Compound 3: middle estimate off by 7.5-fold (0.88 log units), on the high side, and the stated range ends above it.
By their numbers in this assay, from the lowest: compounds 1 and 3 (each within the scatter of the next); then compound 2.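

In this assay the exchange on a saturated chain carbon bound to an oxygen on a saturated carbon gives a 1.3-fold higher number from compound 1 to compound 3 (0.12 log units; within the scatter). The group of 11 heavy atoms, with its non-aromatic ring and its fluorine, can therefore give way to 4-methoxybenzyl without a step beyond the scatter, so that ring and fluorine are not needed for a low number in this pair. Nothing at hand explains why the two groups read alike. Still open, from the compounds shown here alone, is whether this place needs an aromatic ring at all, and how a carboxylic acid or an amine there would read.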